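The compounds below may be only part of what the source reports. "The series", "measured", "known", "first", "only" and "open" are said of these compounds alone.

Measured so far:
Compound 1, `C[C@H]1C[C@H]1C(=O)N1CC2CNCC2C1`, in an assay on CHO cells for displacement of a labelled ligand from Neuronal acetylcholine receptor; alpha3/beta4 (Homo sapiens), read by scintillation counting, with a stated time of 2 h (a lower number here means a stronger inhibitor, a higher number a weaker inhibitor), gives 2000 nM.
Compound 2, `C[C@@H]1C[C@@H]1C(=O)N1CC2CNCC2C1`, in this assay gives 280 nM.

Of the two numbers seen, compound 2 holds the lower one; its nearest neighbour, compound 1, sits a 7.1-fold lower number from compound 1 to compound 2 (0.85 log units; beyond the scatter) away, which is a modest step and beyond the scatter. The only account that the data give for this measured step is the fact that one of compounds 1 and 2 is drawn with a defined configuration and the other without, at the place where they differ.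

Compound 3, `C[C@@H]1C[C@H]1C(=O)N1CC2CNCC2C1`, has not yet been run in this assay. It keeps every atom and bond of compound 2, and the change is confined to the stereochemistry: the two compounds have the same atoms and bonds; at least one stereo element is drawn with a configuration in one of them and without one in the other: 1 of 4 stereo elements differ; a stereocentre at a saturated ring carbon is drawn S in compound 2 and R in compound 3. Within the data shown here, the one measured step, a 7.1-fold lower number from compound 1 to compound 2 (0.85 log units; beyond the scatter), inverted both ring stereocentres at once and moved the number by a modest amount; here only one of them is inverted, so that step is the sole guide, and an imperfect one. A shift back toward the weaker side is the plausible expectation, smaller than or comparable to the measured one. Compound 3 is therefore expected to give about 900 nM in this assay, within a range from 200 nM to 4000 nM. This estimate means a step of a 3.2-fold higher number from compound 2 to compound 3 (0.51 log units; beyond the scatter).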

Compound 3, inhibition constant: 360 nM
Compound 3: the middle estimate sits 2.5-fold (0.40 log units) above what was measured, and the stated range covers the measured number.
By their numbers in this assay, from the lowest: compounds 2 and 3 (each within the scatter of the next); then compound 1.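

Inverting a single ring stereocentre gives a 1.3-fold higher number from compound 2 to compound 3 (0.11 log units; within the scatter), so in this assay this one change does not separate the two compounds. The other single inversion gives a 5.6-fold lower number from compound 1 to compound 3 (0.74 log units; beyond the scatter), which is a modest step and of much the same order as the double inversion seen earlier, a 7.1-fold lower number from compound 1 to compound 2 (0.85 log units; beyond the scatter); the two ring stereocentres therefore do not count equally among these three compounds, and most of the earlier gap is found in this one change. The only account the data give for that gap is this: the fact that one of compounds 1 and 3 is drawn with a defined configuration and the other without, at the place where they differ.

The compounds shown leave open how the remaining arrangement of the two ring stereocentres would read in this assay, so it cannot be said whether the pattern among these three compounds extends to all four arrangements. They also leave open whether the same dependence on configuration would hold if the methyl group were replaced by a longer chain such as ethyl, or by a hydroxymethyl group.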